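This account rests on a few compounds, and the source may have more. Where it says the series, first, only, none or still open, it means among the compounds named here.

In an ADME assay on MT4 cells (Homo sapiens) for cytotoxicity, read by MTT assay, with a stated time of 4 days (on this read-out higher numbers stand for lower toxicity in this test and lower numbers for higher toxicity in this test), compound 3 (`COc1ccc(-c2oc3ccc(N)cc3c(=O)c2O)cc1`) gives 239000 nM and compound 2 (`Nc1ccc2oc(-c3ccccc3)c(O)c(=O)c2c1`) gives 217000 nM, two numbers that stand level. Compound 1 (`CC(=O)Nc1ccc2oc(-c3ccc(F)cc3)c(O)c(=O)c2c1`) gives 34100 nM, well short of both. Compound 4 (`Nc1ccc2oc(-c3ccc(F)cc3)c(O)c(=O)c2c1`) is compound 3 with fluoro in place of methoxy on an aromatic carbon, para to a large group: fluoro in place of methoxy on an aromatic carbon. Among the compounds with values here, the one measured step at this place, methoxy in place of hydrogen, is a 1.1-fold higher number from compound 2 to compound 3 (0.04 log units; within the scatter). Compound 1 with 34100 nM also carries fluoro, but its amino group is acetylated, so it does not isolate that change. No step beyond the scatter is therefore expected in this assay, and the estimated step is a 1.3-fold lower number from compound 3 to compound 4 (0.10 log units; within the scatter). For compound 4 the estimate is 190000 nM, with an expected range of 90000 nM to 320000 nM.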

Compound 4, half-maximal cytotoxic concentration: 92600 nM
Compound 4: the middle estimate sits 2.1-fold (0.31 log units) above what was measured; the measured number falls inside the stated range.
By their numbers in this assay, from the lowest: compound 1; then compound 4; then compounds 2 and 3 (each within the scatter of the next).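

In this assay the aromatic carbon para to a large group now proves sensitive to what it carries: fluoro in place of methoxy gives a 2.6-fold lower number from compound 3 to compound 4 (0.41 log units; beyond the scatter) and fluoro in place of hydrogen gives a 2.3-fold lower number from compound 2 to compound 4 (0.37 log units; beyond the scatter) even though methoxy and hydrogen stand level. With fluoro kept, hydrogen in place of acetyl on the nitrogen gives a 2.7-fold higher number from compound 1 to compound 4 (0.43 log units; beyond the scatter) and so reads that change apart from the others. Nothing shown gives a reason for these steps. Going by these compounds, whether chloro or trifluoromethyl here would follow fluoro, and whether the acetyl step holds without fluoro, stays open.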